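This account rests on a few compounds, and the source may have more. Where it says the series, first, only, none or still open, it means among the compounds named here.

Measured in a functional assay on HepG2 cells (Homo sapiens) for antiproliferative activity, read by MTT assay, with a stated time of 24 h; on this read-out higher numbers stand for weaker inhibition and lower numbers for stronger inhibition:
- compound 1 `C=CCc1cc(-c2cccc(C(F)(F)F)c2)ccc1O`: 58300 nM
- compound 2 `C=CCc1cc(C=O)c(OCC(=O)OCC)c(-c2ccc(OCC(=O)OCC)c(CC=C)c2)c1`: > 85200 nM

Compound 2 reads > 85200 nM, which is a limit of this assay and not a number. Compound 3 `C=CCc1ccc(OCC(=O)OCC)c(-c2ccc(OCC(=O)OCC)c(CC=C)c2)c1` carries hydrogen in place of formyl on an aromatic carbon. For the measured compounds named here, no measured step covers this change, and compound 2 offers no number to start from. No step beyond the usual scatter is expected in this assay, so weak inhibition should persist. The expected change is a number no higher from compound 2 to compound 3 (the limit leaves the size open). The estimate for compound 3 is 85000 nM, within an expected range of 40000 nM to 160000 nM.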

Compound 3, half-maximal inhibitory concentration: 68900 nM
For compound 3 the middle estimate is 1.2-fold (0.09 log units) above the measured one; measured number inside the range.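

In this assay, hydrogen in place of formyl on an aromatic carbon, ortho to a (ethoxycarbonyl)methoxy group, gives an at least 1.2-fold lower number from compound 2 to compound 3 (0.09 log units; that floor lies within the scatter). Compound 3 thus gives this position its first actual number, 68900 nM, on the side without formyl. The size of the step remains only a floor because compound 2 gives a limit of the assay and not a number: the limit of > 85200 nM in this assay, at which 1 of the 3 values shown sits.

The compounds shown leave open how an amine or a carboxylic acid on this aromatic carbon would read in this assay. They also leave open whether any group here gives a step beyond the scatter.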